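Extending the amine side chain of compound 1

The compounds below may be only part of what the source reports. "The series", "measured", "known", "first", "only" and "open" are said of these compounds alone.

Compound 1 `CNc1cc(C)c2cc(NC(=O)c3ccc(Cl)c(Cl)c3)ccc2n1` stands second highest of the three numbers in a functional assay on MCF7 cells (Homo sapiens) for antiproliferative activity, read by MTT assay, with a stated time of 72 h (on this read-out higher numbers stand for weaker inhibition and lower numbers for stronger inhibition), where compound 1 gives 2520 nM. Compound 3 `CCN1CCN(c2cc(C)c3cc(NC(=O)c4ccc(Cl)cc4)ccc3n2)CC1` gives 1530 nM, within the scatter of compound 1, while compound 2 `CCN1CCN(c2cc(C)c3cc(NC(=O)c4cccc(C)c4)ccc3n2)CC1` gives 7800 nM. Going by the values given here, the only single-point step measured, a 5.1-fold lower number from compound 2 to compound 3 (0.71 log units; beyond the scatter), alters the aryl on the carbonyl and not the amine side of the shared core. Compound 4 `CCN(CC)CCNc1cc(C)c2cc(NC(=O)c3ccc(Cl)c(Cl)c3)ccc2n1` differs from compound 1 by (diethylamino)methyl in place of hydrogen on a saturated chain carbon bound to a nitrogen on an aromatic ring. Among the compounds with values here, no measured step touches this position, so the expectation rests on compound 1 alone, and no step beyond the scatter is expected in this assay. Compound 4 is therefore estimated at 2000 nM, between 600 nM and 7000 nM, an expected step of a 1.3-fold lower number from compound 1 to compound 4 (0.10 log units; within the scatter).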

Compound 4, half-maximal inhibitory concentration: 1420 nM
Compound 4: the middle estimate sits 1.4-fold (0.15 log units) above what was measured; measured number inside the range.
By their numbers in this assay, from the lowest: compounds 4, 3 and 1 (each within the scatter of the next); then compound 2.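

In this assay, going by these compounds alone, this is the first step measured at this position: a 1.8-fold lower number from compound 1 to compound 4 (0.25 log units; within the scatter). The two numbers cannot be told apart, so this position carries 2-(diethylamino)ethyl in place of methyl on the amine without a step beyond the scatter. No measurement available here bears on why this is so. Still open, as far as these compounds go, is whether a longer chain, or a carboxylic acid in place of the diethylamino end, would give a step beyond the scatter at this position.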